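This account rests on a few compounds, and the source may have more. Where it says the series, first, only, none or still open, it means among the compounds named here.

Among the compounds with values here, in a functional assay, with a stated time of 90 s (on this read-out lower numbers stand for stronger inhibition and higher numbers for weaker inhibition), compound 1 (`Cc1nc2c3ccccc3ccc2c2nc3c(ccc4ccccc43)c(-c3nccnc3N)c12`) reads 134 ug/mL and compound 2 (`Cc1nc2c3ccccc3ccc2c2nc3c(ccc4ccccc43)c(-c3ccccc3N)c12`) reads 125 ug/mL on the same core, and these are the only two numbers available. Compound 2 therefore has a single neighbour, and the two values lie within the scatter of repeated measurements, so neither can be ranked. Compound 3 (`Cc1nc2c3ccccc3ccc2c2nc3c(ccc4ccccc43)c(-c3cc(O)nc4ccccc34)c12`) keeps that core but carries 2-hydroxyquinolin-4-yl in place of 2-aminophenyl on an aromatic carbon, opposite the ring nitrogen (2-hydroxyquinolin-4-yl in place of 2-aminophenyl on an aromatic carbon). Within the data shown here, one measured step bears on this change, the exchange of one aromatic group for another on that carbon, and it gave a 1.1-fold lower number from compound 1 to compound 2 (0.03 log units; within the scatter) with no shift beyond the scatter. Among the measured compounds shown here, the entering group holds more heavy atoms than either group measured so far, and no measured compound shows what that does, so the direction stays open. For the measured compounds named here, with that single step as the only guide, no change beyond the scatter is expected in this assay here. This means an estimated step (a 1.0-fold lower number from compound 2 to compound 3 (0.02 log units; within the scatter)). For compound 3 the expected value is 120 ug/mL (estimated range 55 ug/mL to 250 ug/mL).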

Compound 3, half-maximal inhibitory concentration: 148 ug/mL
For compound 3 the middle estimate is 1.2-fold (0.09 log units) below the measured one, and the stated range covers the measured number.
By their numbers in this assay, from the lowest: compounds 2, 1 and 3 (each within the scatter of the next).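

In this assay, placing 2-hydroxyquinolin-4-yl on this aromatic carbon in place of 2-aminophenyl gives a 1.2-fold higher number from compound 2 to compound 3 (0.07 log units; within the scatter), and placing it there in place of 3-aminopyrazin-2-yl gives a 1.1-fold higher number from compound 1 to compound 3 (0.04 log units; within the scatter). The earlier compounds shown here carried only single-ring groups at this position, opposite the ring nitrogen, whereas the entering group has 11 heavy atoms and two six-membered aromatic rings, yet all three numbers stay within the scatter of one another and cannot be ranked. No supporting evidence is available to explain these close values.

On these data alone, every group compared so far joins the core through an aromatic ring, so the effect of a carboxylic acid, a simple amine or a longer alkyl chain on this carbon remains open. As far as these compounds go, it is also open whether any replacement at this position can produce a step beyond the scatter in this assay, in either direction.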